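A few compounds are considered here, and "the series" means these few. Any claim that something is new, unique, unknown or untested is made for them only; others in the source may bear on it.

Measured so far in a functional assay on CHO cells for antagonist activity at prostaglandin E2 receptor EP1 subtype (Homo sapiens), read by FLIPR and calcium flux; a lower number here means a stronger inhibitor, a higher number a weaker inhibitor:
- compound 1, `COc1ccc(Cc2nnc(CN(c3cccc(Cl)c3Cl)S(=O)(=O)c3ccc(C)cc3)o2)cc1`: 39.8 nM
- compound 2, `Cc1ccc(S(=O)(=O)N(Cc2nnc(Cc3ccc(F)cc3)o2)c2cccc(Cl)c2C)cc1`: 501 nM

Compound 2 holds the higher of the two numbers recorded in this assay; compound 1 gives the lower one, and the gap between them lies beyond the scatter. For the measured compounds named here, the two differ in several places at once, so no single step between them is counted, and the comparison says only that much.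

Compound 3, `Cc1ccc(S(=O)(=O)N(Cc2nnc(Cc3c(Cl)cccc3Cl)o2)c2cccc(Cl)c2C)cc1`, is not yet measured. Relative to compound 2 it carries 2,6-dichlorophenyl in place of 4-fluorophenyl on a saturated chain carbon bound to an aromatic carbon, the rest of the structure being unchanged. Going by the values given here, no measured pair shows this exchange on its own, so the size of the step rests on no direct precedent. The working expectation is a change of modest size, in either direction, not clearly beyond the scatter: for compound 3 in this assay the estimate is 400 nM, within 100 nM to 1600 nM, which amounts to an expected step of a 1.3-fold lower number from compound 2 to compound 3 (0.10 log units; within the scatter).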

Compound 3, inhibition constant: 501 nM
Compound 3: the middle estimate sits 1.3-fold (0.10 log units) below what was measured; low and high end bracket the measured number.
By their numbers in this assay, from the lowest: compound 1; then compounds 2 and 3 (each within the scatter of the next).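

Read in this assay, putting 2,6-dichlorophenyl in place of 4-fluorophenyl on a saturated chain carbon bound to an aromatic carbon gives no change at the digits printed from compound 2 to compound 3 (within the scatter). For the compounds shown here, this is the only single-place step so far, and it shows that this position takes the 2,6-dichlorophenyl group, with two chlorines in place of one fluorine, without a step beyond the scatter. No measurement shown accounts for this result.

From the compounds shown here alone, whether this position responds to any other kind of group remains open, for example a carboxylic acid, an amine or a longer chain in place of the substituted phenyl. Also open, going by these compounds, is whether the same exchange gives a similar step on the core of compound 1, or whether the outcome depends on the rest of the structure.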